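Moving the Chlorine on the Pyridine Ring

A few compounds are considered here, and "the series" means these few. Any claim that something is new, unique, unknown or untested is made for them only; others in the source may bear on it.

Measured so far in a functional assay on NCI-H460 cells (Homo sapiens) for antiproliferative activity, read by MTT assay, with a stated time of 48 h; a lower number here means a stronger inhibitor, a higher number a weaker inhibitor:
Compound 1, `O=C(CCl)Nc1ccc(SCC(=O)Nc2cc(Cl)ccn2)cc1`, gives 5600 nM.
Compound 2, `O=C(CCCl)Nc1ccc(SCC(=O)Nc2cc(Cl)ccn2)cc1`, gives 10900 nM.
Compound 3, `CC(C)(C)C(=O)Nc1ccc(SCC(=O)Nc2ccc(Cl)cn2)cc1`, gives 67200 nM.

Compound 3 has the highest number of the three, lying well beyond the scatter from both compound 2 and compound 1. Within the data shown here, the only single-place step among the measured compounds is a 1.9-fold higher number from compound 1 to compound 2 (0.29 log units; within the scatter), which concerns the acyl chain and not the pyridine ring. Compound 4, `CC(C)(C)C(=O)Nc1ccc(SCC(=O)Nc2cc(Cl)ccn2)cc1`, differs from compound 3 by 4-chloropyridin-2-yl in place of 5-chloropyridin-2-yl on an amide-type nitrogen. Compounds 1 and 2 carry the 4-chloropyridin-2-yl group and show lower numbers than compound 3, but they also differ from it in the acyl group, so the two changes cannot be separated. Among the measured compounds shown here, no measured step therefore bears directly on the change from compound 3 to compound 4. The step is expected to be small to moderate, as a 1.7-fold lower number from compound 3 to compound 4 (0.23 log units; within the scatter), leaning toward a lower number. Compound 4 is estimated at 40000 nM, with a range from 12000 nM to 130000 nM.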

Compound 4, half-maximal inhibitory concentration: 35300 nM
For compound 4 the middle estimate is 1.1-fold (0.05 log units) above the measured one; low and high end bracket the measured number.
By their numbers in this assay, from the lowest: compounds 1 and 2 (each within the scatter of the next); then compounds 4 and 3 (each within the scatter of the next).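

In this assay, 4-chloropyridin-2-yl in place of 5-chloropyridin-2-yl on the amide-type nitrogen gives a 1.9-fold lower number from compound 3 to compound 4 (0.28 log units; within the scatter), so the chlorine change, now read on its own, stays within the usual scatter. With 4-chloropyridin-2-yl held constant, the acyl change can also be read: tert-butyl in place of 2-chloroethyl gives a 3.2-fold higher number from compound 2 to compound 4 (0.51 log units; beyond the scatter), and tert-butyl in place of chloromethyl gives a 6.3-fold higher number from compound 1 to compound 4 (0.80 log units; beyond the scatter). Among these single-place steps, the two on the carbonyl carbon lie beyond the scatter, while the one on the amide-type nitrogen does not.

Nothing shown explains any of these steps. On these data alone, it remains open whether the chlorine change would read the same alongside chloromethyl or 2-chloroethyl, and how an amine or a methoxy group in place of the chlorine would compare.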